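This account rests on a few compounds, and the source may have more. Where it says the series, first, only, none or still open, it means among the compounds named here.

Measured compounds:
compound 1 `O=C(O)COc1ccc(NCc2cccc(-c3ccccc3)c2)cc1F` — 58.5 nM
compound 2 `COc1ccccc1-c1cccc(CNc2ccc(OCC(=O)O)c(F)c2)c1` — 536 nM
compound 3 `Cc1ccc(-c2cccc(CNc3ccc(OCC(=O)O)c(F)c3)c2)c(Cl)c1` — 22.5 nM

In a functional assay on CHO cells for agonist activity at Free fatty acid receptor 1 (Homo sapiens), read by FLIPR and calcium flux (a lower number here means that less compound is needed, a higher number that more compound is needed for the effect), compound 3 gives the lowest number of the three. Its nearest neighbour is compound 1 with 58.5 nM, the step being a 2.6-fold lower number from compound 1 to compound 3 (0.41 log units; beyond the scatter); the furthest is compound 2, the step being a 24-fold lower number from compound 2 to compound 3 (1.38 log units; beyond the scatter).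

Compound 4 `CCOc1ccc(-c2cccc(CNc3ccc(OCC(=O)O)c(F)c3)c2)c(C)c1` differs from compound 3 in one place: 4-ethoxy-2-methylphenyl in place of 2-chloro-4-methylphenyl on an aromatic carbon. The aryl ring attached to the shared core keeps a small group in the position that carried chlorine, now methyl, while the methyl group that sat on the far side of that ring is replaced by ethoxy.

Among the measured compounds shown here, two measured steps bear on this. The step of a 9.2-fold higher number from compound 1 to compound 2 (0.96 log units; beyond the scatter) shows that adding an oxygen-bearing group to the pendant phenyl ring can weaken the response markedly. The step of a 2.6-fold lower number from compound 1 to compound 3 (0.41 log units; beyond the scatter) shows that the 2-chloro-4-methyl pattern improves it modestly. Compound 4 keeps a substituent in the first of those two positions but introduces an ethoxy group in the second, for which no direct comparison exists. A modest step, more likely upward than downward, is therefore expected; a 2.0-fold higher number from compound 3 to compound 4 (0.30 log units; within the scatter) is the estimated change. For compound 4 the expected value in this assay is 45 nM, within 14 nM to 140 nM.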

Compound 4, half-maximal effective concentration: 11.6 nM
Estimate against measurement, compound 4: 3.9-fold (0.59 log units) above, and the stated range ends above it.
By their numbers in this assay, from the lowest: compounds 4 and 3 (each within the scatter of the next); then compound 1; then compound 2.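

In this assay, the exchange of 2-chloro-4-methylphenyl for 4-ethoxy-2-methylphenyl (a 1.9-fold lower number from compound 3 to compound 4 (0.29 log units; within the scatter)) leaves the two compounds indistinguishable, so this place on the aromatic carbon accommodates an ethoxy-bearing aryl group as well as the chlorine-bearing one. Read against the plain phenyl (a 5.0-fold lower number from compound 1 to compound 4 (0.70 log units; beyond the scatter)) and against the 2-methoxyphenyl (a 46-fold lower number from compound 2 to compound 4 (1.66 log units; beyond the scatter)), the result shows that an ether oxygen on the pendant ring does not by itself bring the high number seen with compound 2; compound 2 and compound 4 both carry such an oxygen, yet they sit at opposite ends of the series. No measured evidence accompanies these results to account for the contrast between the two oxygen-bearing groups.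

Still open, as far as these compounds go, is how much of the standing of compound 4 belongs to the methyl group and how much to the ethoxy group, as the two appear together in a single substituent. Also open, from the compounds shown here alone, is whether a longer chain such as propoxy, or an amine or a carboxylic acid in place of the ethoxy group, would keep the number in the range of compound 3 and compound 4.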